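This account rests on a few compounds, and the source may have more. Where it says the series, first, only, none or still open, it means among the compounds named here.

In an ADME assay on microsomes from liver (Homo sapiens) for metabolic stability, read by LC-MS, using NADPH, with stated times of 10 min and 30 min (on this read-out lower numbers stand for slow clearance and higher numbers for fast clearance), compound 3 (`CC(=O)N[C@@H]1CCCc2c1cncc2N1C(=O)c2ccc(Cl)cc2[C@@H]1C`) gives < 3.5 mL/min/kg as a limit of the assay and not a number. Compound 2 (`CCC(=O)N[C@@H]1CCCc2c1cncc2N1C(=O)c2ccc(Cl)cc2[C@@H]1C`) gives < 3.5 mL/min/kg as a limit as well. Compound 3 thus stands at the limit of < 3.5 mL/min/kg in this assay, at which 2 of the 3 values shown sit, and has no exact value to start from. Compound 4 (`CC(=O)N[C@@H]1CCCc2c1cncc2N1Cc2cc(Cl)ccc2C1=O`) carries one structural change relative to compound 3, hydrogen in place of methyl on a saturated ring carbon and, in short, hydrogen in place of methyl on a saturated ring carbon, next to the ring nitrogen. The closest measured change is also a swap of methyl for hydrogen, but on a saturated chain carbon bound to a carbonyl carbon. It appears as a step that the two limits leave unreadable from compound 2 to compound 3 and so offers no size to carry over. Going by the values given here, the only true number comes from compound 1 (`O=C1c2ccc(Cl)cc2CN1c1cccnc1`), whose 12.8 mL/min/kg shows that a measurable clearance does occur in this small set. The change in this assay is therefore expected to be small, either within the scatter or slightly toward faster clearance, and the estimated move is an at least 1.1-fold higher number from compound 3 to compound 4 (0.05 log units; that floor lies within the scatter) on this read-out. For compound 4 the expected clearance is 4 mL/min/kg as the estimate, with a likely range from 2.5 mL/min/kg to 8 mL/min/kg in this assay.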

Compound 4, clearance: < 3.5 mL/min/kg
Compound 4 was reported as a limit (the forecaster's own chance of this, stated with the estimate: 50%); middle value at least 1.1-fold (0.05 log units) away from the limit.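

No size can be read for the change from compound 3 to compound 4, because both are reported only as limits of the assay and not as numbers: the limit of < 3.5 mL/min/kg in this assay, at which 3 of the 4 values shown sit.

The compounds shown leave open the actual clearance of compound 2, compound 3 and compound 4, and so whether replacing methyl with hydrogen on the saturated ring carbon changes it at all.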